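Fluoro to Methyl on the Aryl of Compound 3

This account rests on a few compounds, and the source may have more. Where it says the series, first, only, none or still open, it means among the compounds named here.

In an ADME assay on Vero cells (Chlorocebus sabaeus) for cytotoxicity, read by MTT assay, with a stated time of 72 h (a lower number here means that less compound is tolerated, a higher number that more compound is tolerated), compound 3 `COc1ccc(C2=NN(c3ccc(S(N)(=O)=O)cc3)C(c3cn(-c4ccccc4)nc3-c3ccc(F)cc3)C2)cc1` gives only a limit, > 53100 nM. Compound 1 `NS(=O)(=O)c1ccc(N2N=C(c3ccc(Br)cc3)CC2c2cn(-c3ccccc3)nc2-c2ccc(F)cc2)cc1` gives 49400 nM. Compound 2 `NS(=O)(=O)c1ccc(N2N=C(c3ccc(F)cc3)CC2c2cn(-c3ccccc3)nc2-c2ccc(F)cc2)cc1` likewise gives only a limit, > 753000 nM. The measured swaps, an at least 15-fold higher number from compound 1 to compound 2 (1.18 log units; beyond the scatter) and an at least 1.0-fold higher number from compound 1 to compound 3 (0.03 log units; that floor lies within the scatter), all sit elsewhere in the shared core, and the step that the two limits leave unreadable from compound 2 to compound 3 cannot be read because the limit of > 753000 nM in this assay, at which 1 of the 3 values shown sits, and the limit of > 53100 nM in this assay, at which 1 of the 3 values shown sits, bound it on both sides. Compound 4 `COc1ccc(C2=NN(c3ccc(S(N)(=O)=O)cc3)C(c3cn(-c4ccccc4)nc3-c3ccc(C)cc3)C2)cc1` differs from compound 3 by methyl in place of fluoro on an aromatic carbon. Within the data shown here, no measured step touches this change, so no shift beyond the scatter is expected in this assay, and a limit is again likely. Compound 4 is therefore estimated at 60000 nM, within 25000 nM to 300000 nM. The expected step is a step that the limit leaves unreadable from compound 3 to compound 4, inside the scatter.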

Compound 4, half-maximal cytotoxic concentration: > 36600 nM
Compound 4: only a limit was reported; the forecaster's own chance of this, stated with the estimate: 60%; the middle value is on the limit's open side.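

In this assay compound 4 gives only a limit, > 36600 nM. Among these compounds, compound 3 likewise gives only a limit, > 53100 nM, and no step between compound 3 and compound 4 can be read. The compounds shown leave open whether methyl in place of fluoro shifts the half-maximal cytotoxic concentration in this assay.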